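This account rests on a few compounds, and the source may have more. Where it says the series, first, only, none or still open, it means among the compounds named here.

Compound 1 `O=C(CCc1cccc2c1B(O)OC2)Nc1ccccc1` and compound 2 `COc1ccccc1NC(=O)CCc1cccc2c1B(O)OC2` share one core and differ by the change (methoxy in place of hydrogen on an aromatic carbon). In a functional assay on MDA-MB-231 cells (Homo sapiens) for antiproliferative activity, read by MTT assay, with a stated time of 72 h (a lower number here means a stronger inhibitor, a higher number a weaker inhibitor), compound 1 gives 230 nM, while compound 2 gives 930 nM; that change produced a 4.0-fold higher number from compound 1 to compound 2 (0.61 log units; beyond the scatter).

Compound 3 `COc1cccc(-c2cccc(NC(=O)CCc3ccc4c(c3)COB4O)c2)c1` is built on a different core, and the difference between the two cores is not broken down here. In this assay compound 3 gives 90000 nM, the highest number of the three measured compounds and far apart from both compound 1 and compound 2.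

Compound 4 `COc1cc(OC)cc(-c2cccc(NC(=O)CCc3ccc4c(c3)COB4O)c2)c1` has not yet been measured. It differs from compound 3 by methoxy in place of hydrogen on an aromatic carbon. Among the compounds with values here, this is the same kind of change as the one between compound 1 and compound 2, but the surroundings are not the same: in compound 2 the entering methoxy sits ortho to a large group, whereas in compound 4 it sits meta to a large group and meta to a methoxy group. Within the data shown here, because the only measured example of this change gave a 4.0-fold higher number from compound 1 to compound 2 (0.61 log units; beyond the scatter), and because compound 3 already stands at 90000 nM, a further weakening of roughly comparable size is expected, a 2.0-fold higher number from compound 3 to compound 4 (0.30 log units; within the scatter). With that reasoning, compound 4 is estimated to give about 180000 nM in this assay, most likely between 50000 nM and 500000 nM, with a real chance that only a limit is reported.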

Compound 4, half-maximal inhibitory concentration: 77000 nM
Beside the measured number, compound 4's estimate is 2.3-fold (0.37 log units) above it, and the stated range covers the measured number.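

In this assay, going from 3-methoxyphenyl to 3,5-dimethoxyphenyl gave a 1.2-fold lower number from compound 3 to compound 4 (0.07 log units; within the scatter), so on this core the added methoxy produced no readable difference, whereas the same kind of change on the core of compound 1 gave a 4.0-fold higher number from compound 1 to compound 2 (0.61 log units; beyond the scatter). The effect of this change therefore did not carry over unaltered from one core to the other in this series: the same change on two cores in this assay, a 4.0-fold higher number (0.61 log units; beyond the scatter) from compound 1 to compound 2 and a 1.2-fold lower number (0.07 log units; within the scatter) from compound 3 to compound 4, 4.7-fold (0.67 log units) apart, beyond the scatter of two such steps. Within the data shown here, this does not show why the two steps differ or how the change would behave on any further core, since the evidence is only two pairs, and these differ both in the core and in the surroundings of the entering methoxy, so the data cannot separate those influences.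

The compounds shown leave open whether the difference follows the core itself or the place of the methoxy, as no methoxy is seen in the same surroundings on both cores. They also leave open how an amine, a carboxylic acid or a hydroxyl group in place of the methoxy would behave on either core, and whether a longer chain linking the amide to the core would alter these steps.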